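Moving the Methoxy Group on the Benzyl Arm

The source may hold more compounds than are shown below. What is called first, only, known or untested is meant among the compounds shown, and "the series" means these compounds.

Measured compounds and their values:
compound 1, `Nc1cccc(-c2cn3nc(Cc4ccccc4)sc3n2)c1`: 7400 nM
compound 2, `Nc1cccc(-c2cn3nc(Cc4ccc(Cl)cc4)sc3n2)c1`: 16000 nM
compound 3, `COc1ccc(Cc2nn3cc(-c4cccc(N)c4)nc3s2)cc1`: 227000 nM

All three were tested in a functional assay on L1210 cells (Mus musculus) for inhibition, read by cell counting, with a stated time of 2 days; a higher number here means a weaker inhibitor, a lower number a stronger inhibitor. Compound 3 stands highest of the three numbers; compound 2 is nearest to it, and compound 1 is furthest away. Compound 4, `COc1cccc(Cc2nn3cc(-c4cccc(N)c4)nc3s2)c1`, has not yet been measured. It differs from compound 3 in one place: 3-methoxyphenyl in place of 4-methoxyphenyl on a saturated chain carbon bound to an aromatic carbon. The measured steps that touch the same ring are a 31-fold higher number from compound 1 to compound 3 (1.49 log units; beyond the scatter) and a 14-fold higher number from compound 2 to compound 3 (1.15 log units; beyond the scatter), both showing a large rise in the number once a methoxy group sits where compound 3 carries it, while a 2.2-fold higher number from compound 1 to compound 2 (0.33 log units; beyond the scatter) shows a smaller rise for chloro at that same place. For the measured compounds named here, no measured step moves a group to a different place on this ring, so the data give no direct guide for compound 4. Due to a 31-fold higher number from compound 1 to compound 3 (1.49 log units; beyond the scatter), compound 4 is expected to sit somewhere between compound 1 and compound 3, with a wide range. Compound 4 is expected to give about 70000 nM, between 12000 nM and 300000 nM. That estimate means an expected step of a 3.2-fold lower number from compound 3 to compound 4 (0.51 log units; beyond the scatter).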

Compound 4, half-maximal inhibitory concentration: 21000 nM
Compound 4: the middle estimate sits 3.3-fold (0.52 log units) above what was measured; the range from low to high includes it.
By their numbers in this assay, from the lowest: compound 1; then compounds 2 and 4 (each within the scatter of the next); then compound 3.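

In this assay, moving the methoxy group gives an 11-fold lower number from compound 3 to compound 4 (1.03 log units; beyond the scatter), so on this ring the result depends on where the methoxy sits and not only on whether it is present. With 3-methoxyphenyl on the saturated chain carbon, adding methoxy to the plain phenyl ring costs far less than it did as 4-methoxyphenyl: the step is a 2.8-fold higher number from compound 1 to compound 4 (0.45 log units; beyond the scatter), which is only modest. The comparison with the chloro compound gives a 1.3-fold higher number from compound 2 to compound 4 (0.12 log units; within the scatter), so compound 4 and compound 2 cannot be told apart in this assay.

No data shown here explain why the two methoxy placements differ so sharply. As far as these compounds go, whether chloro responds to the same move, and how a hydroxyl group or an amine on this ring would compare, remains open.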